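A few compounds are considered here, and "the series" means these few. Any claim that something is new, unique, unknown or untested is made for them only; others in the source may bear on it.

Measured in an ADME assay on a cell-free system (serum, Homo sapiens) for metabolic stability, read by HPLC, tested at 2 mM; on this read-out lower numbers stand for a shorter-lived compound and higher numbers for a longer-lived compound:

compound 1 `O=C(O[C@H]1C[C@H](n2cc(F)c(=O)[nH]c2=O)O[C@@H]1COP(=O)(O)Oc1ccccc1)c1ccccc1` — compound 1 gives 5.1 h
compound 2 `O=C(O[C@H]1C[C@H](n2cc(F)c(=O)[nH]c2=O)O[C@@H]1COP(=O)(O)Oc1cccnc1)c1ccccc1` — compound 2 gives 17.8 h
compound 3 `O=C(O[C@H]1C[C@H](n2cc(F)c(=O)[nH]c2=O)O[C@@H]1COP(=O)(O)Oc1ccc2ncccc2c1)c1ccccc1` — compound 3 gives 16.5 h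

Compound 2 holds the highest number of the three, but a 1.1-fold lower number from compound 2 to compound 3 (0.03 log units; within the scatter) keeps compound 3 within the scatter of it, so the two cannot be ordered. The clear gap is to compound 1: a 3.5-fold higher number from compound 1 to compound 2 (0.54 log units; beyond the scatter) and, in parallel, a 3.2-fold higher number from compound 1 to compound 3 (0.51 log units; beyond the scatter) both lie beyond the scatter, showing that either ring with one hetero atom in place of phenyl on the oxygen goes with a longer-lived compound.

Compound 4 `C[n+]1cccc(OP(=O)([O-])OC[C@H]2O[C@@H](n3cc(F)c(=O)[nH]c3=O)C[C@@H]2OC(=O)c2ccccc2)c1` differs from compound 2 in this way: a group of 11 heavy atoms (6 carbon, 1 nitrogen, 3 oxygen, 1 phosphorus; one six-membered aromatic ring with 1 hetero atom) in place of a group of 10 heavy atoms (5 carbon, 1 nitrogen, 3 oxygen, 1 phosphorus; one six-membered aromatic ring with 1 hetero atom), on an oxygen on a saturated carbon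

Within the data shown here, no measured step covers this change; the three steps seen all concern which aryl group sits on the oxygen, and none of them alters the count of hydrogen-bond donors. The expected step of a 1.3-fold lower number from compound 2 to compound 4 (0.10 log units; within the scatter) is therefore set near none beyond the scatter, with a wide range in either direction. Compound 4 is expected to give 14 h, between 5 h and 40 h.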

Compound 4, half-life: 37.3 h
Beside the measured number, compound 4's estimate is 2.7-fold (0.43 log units) below it; the range from low to high includes it.
By their numbers in this assay, from the lowest: compound 1; then compounds 3 and 2 (each within the scatter of the next); then compound 4.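

In this assay the position on the oxygen still responds when the aromatic ring type is held, as a 2.1-fold higher number from compound 2 to compound 4 (0.32 log units; beyond the scatter) lies beyond the scatter. Among these compounds, the entering group of 11 heavy atoms has 0 hydrogen-bond donors and the group it replaces has 1 hydrogen-bond donor, a kind of change that none of the earlier steps covered. Against the group with the ring of carbon only, the same entering group gives a 7.3-fold higher number from compound 1 to compound 4 (0.86 log units; beyond the scatter) and so marks the largest step in the series so far, though no evidence here bears on what lies behind the rise.

Among the compounds shown here, compound 4 is the only compound with this type of group, so it stays open whether the same change on the quinolin-6-yl group of compound 3 would give a similar step. From the compounds shown here alone, how an amine or a carboxylic acid in place of the aromatic group on the oxygen would compare also stays open.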